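Swapping naphthyl for dimethoxyphenyl on a weak aorta inhibitor

This account rests on a few compounds, and the source may have more. Where it says the series, first, only, none or still open, it means among the compounds named here.

Among the measured compounds shown here, compound 2 `CCOc1nc(-c2cc3ccccc3o2)cc(-c2cccc3ccccc23)c1C#N` holds the lowest of the two numbers measured so far in a functional assay on aorta (strain Wistar) for inhibition, with Thoracic aorta (Rattus norvegicus) as the target (on this read-out higher numbers stand for weaker inhibition and lower numbers for stronger inhibition), giving 344000 nM. For the measured compounds named here, compound 1 `COc1nc(-c2cc3ccccc3o2)cc(-c2cccc3ccccc23)c1C#N` gives 359000 nM in this assay, and the only step known, a 1.0-fold lower number from compound 1 to compound 2 (0.02 log units; within the scatter), lies within the scatter, so the two compounds cannot be ordered. Compound 3 `CCOc1nc(-c2cc3ccccc3o2)cc(-c2ccc(OC)cc2OC)c1C#N` differs from compound 2 by 2,4-dimethoxyphenyl in place of naphthalen-1-yl on an aromatic carbon. Going by the values given here, no measured step touches this position: the single step known alters only the ethoxy group and carries no information about exchanging one aryl group for another. With nothing pointing either way, compound 3 is expected to show no step beyond the scatter, a 1.1-fold lower number from compound 2 to compound 3 (0.06 log units; within the scatter), though the range must be wide. The estimate for compound 3 in this assay is 300000 nM, expected to fall between 80000 nM and 1200000 nM.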

Compound 3, half-maximal inhibitory concentration: 488000 nM
Compound 3: middle estimate off by 1.6-fold (0.21 log units), on the low side; the range from low to high includes it.
By their numbers in this assay, from the lowest: compounds 2, 1 and 3 (each within the scatter of the next).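

In this assay, the exchange at the aromatic carbon opposite the ring nitrogen gives a 1.4-fold higher number from compound 2 to compound 3 (0.15 log units; within the scatter), so compound 2 and compound 3 cannot be ordered. Among the compounds shown here, this is the first reading at this position, and it shows that replacing naphthalen-1-yl, with its 2 six-membered aromatic rings of carbon only and 0 hydrogen-bond acceptors, by 2,4-dimethoxyphenyl, with one such ring and 2 hydrogen-bond acceptors, moves the number by no more than the scatter. Nothing available gives a reason for this result.

Still open, going by these compounds, is whether an amine or a carboxylic acid on this aryl group would produce a step beyond the scatter. Also open, on these data alone, is whether 2,4-dimethoxyphenyl would read the same alongside a methoxy group, as in the core of compound 1, or a longer chain in place of ethoxy.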